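From compound 2 to compound 4: one hydroxy removed

The source may hold more compounds than are shown below. What is called first, only, known or untested is meant among the compounds shown, and "the series" means these compounds.

Measured so far in a functional assay on MCF7 cells (Homo sapiens) for cytotoxicity, read by sulforhodamine B assay, with a stated time of 48 h; a higher number here means a weaker inhibitor, a lower number a stronger inhibitor:
Compound 1 `COc1ccc(/C=C/C(=O)c2ccc(N)c(-c3ccc(F)cc3)c2)cc1`: 7580 nM
Compound 2 `COc1ccc(/C=C/C(=O)c2cccc(-c3cccc(F)c3)c2)cc1O`: "not determined" (no result reported)
Compound 3 `O=C(/C=C/c1cccc(-c2ccc(F)cc2)c1)c1ccc(O)cc1`: 10800 nM

Compound 2 holds no place on the scale of this assay, since its entry reads "not determined" (no result reported). Going by the values given here, the only numbers available come from two compounds that differ from it in more than one place, and these two values lie within the usual scatter of each other.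

The compound now awaiting its result is compound 4 `COc1ccc(/C=C/C(=O)c2cccc(-c3cccc(F)c3)c2)cc1`. It departs from compound 2 by a single change (hydrogen in place of hydroxy on an aromatic carbon), with hydrogen in place of hydroxy on an aromatic carbon, ortho to a methoxy group.

Among the compounds with values here, with no number for compound 2, this step cannot be read from the data, and no measured pair shows what such a change does. The expectation is therefore for no step beyond the scatter and no particular direction. It rests on the level set by compound 1 at 7580 nM and by compound 3 at 10800 nM, and that basis is thin.

For compound 4 the estimated value is 10000 nM, with an expected range from 3500 nM to 30000 nM.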

Compound 4, half-maximal inhibitory concentration: 3080 nM
Compound 4: middle estimate off by 3.2-fold (0.51 log units), on the high side, outside the stated range (below it).
By their numbers in this assay, from the lowest: compound 4; then compounds 1 and 3 (each within the scatter of the next).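

In this assay compound 4 gives 3080 nM, but compound 2 has no number to set against it, so no step can be read between them. No evidence at hand bears on this result. The compounds shown leave open what hydrogen in place of hydroxy, ortho to a methoxy group, does to cytotoxicity here.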